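The source may hold more compounds than are shown below. What is called first, only, known or untested is meant among the compounds shown, and "the series" means these compounds.

In a functional assay on 786-0 cells (Homo sapiens) for inhibition, read by sulforhodamine B assay, with a stated time of 48 h (a lower number here means a stronger inhibitor of growth, a higher number a weaker inhibitor of growth), compound 3 `COc1cc(C)cc(-c2nn(CC#N)cc2-c2ccnc(-c3ccc(N(C)C)cc3)c2)c1` gives 5430 nM. Its nearest neighbour, compound 2 `Cc1cc(O)cc(-c2nn(CC#N)cc2-c2ccnc(-c3ccc(Oc4ccccc4)cc3)c2)c1`, gives 5380 nM, and the two numbers lie within the scatter of each other, so neither stands apart. Compound 1 `COc1cc(C)cc(-c2c(-c3ccnc(-c4ccc(C(C)=O)cc4)c3)cnn2CC#N)c1` returns only a limit in this assay, > 100000 nM. Compound 4 `Cc1cc(O)cc(-c2nn(CC#N)cc2-c2ccnc(-c3ccc(N(C)C)cc3)c2)c1` differs from compound 3 by a single change, hydrogen in place of methyl on an oxygen on an aromatic ring. Among the compounds with values here, no measured pair isolates this change, so its size cannot be read from the data in hand. Compound 4 is expected to give a step of a 1.1-fold lower number from compound 3 to compound 4 (0.04 log units; within the scatter), inside the scatter. Compound 4 is therefore estimated at 5000 nM, with a range from 1500 nM to 16000 nM.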

Compound 4, concentration for total growth inhibition: 16600 nM
The estimate for compound 4 lay 3.3-fold (0.52 log units) below the measured number; the whole stated range lies below it.
By their numbers in this assay, from the lowest: compounds 2 and 3 (each within the scatter of the next); then compound 4. At a limit, above all of these: compound 1.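

Methoxy to hydroxy on this aromatic ring is not a neutral exchange: in this assay it gives a 3.1-fold higher number from compound 3 to compound 4 (0.49 log units; beyond the scatter). With the hydroxy group held in place, the other end of the molecule also matters, since dimethylamino in place of phenoxy gives a 3.1-fold higher number from compound 2 to compound 4 (0.49 log units; beyond the scatter). Nothing in the data at hand accounts for either step. From the compounds shown here alone, whether the methoxy to hydroxy step keeps its size with phenoxy in place of dimethylamino remains open. So does what an ethoxy group or an amine would give on that aromatic ring.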